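Methoxy for fluoro on the sulfonyl aryl ring

The compounds below may be only part of what the source reports. "The series", "measured", "known", "first", "only" and "open" are said of these compounds alone.

Two compounds of this series have been run in a functional assay on A549 cells (Homo sapiens) for cytotoxicity, read by MTT assay, with a stated time of 72 h; on this read-out higher numbers stand for weaker inhibition and lower numbers for stronger inhibition. Compound 1 `COc1cc2c(Oc3ccc(NC(=O)/C=C/S(=O)(=O)c4ccccc4OC)cc3F)ccnc2cc1OCCCN1CCN(C)CC1` gives 320 nM in this assay. Compound 2 `COc1cc2c(Oc3ccc(NC(=O)/C=C/S(=O)(=O)c4ccccc4F)cc3F)ccnc2cc1OCCCN1CCC(C)CC1` gives 410 nM in this assay. Compound 2 stands at the upper end of the two numbers, but the gap to compound 1 is within the scatter, so the two read as equal. Within the data shown here, compound 1 and compound 2 differ in two places at once, so no single step can be taken from that pair.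

Compound 3 `COc1cc2c(Oc3ccc(NC(=O)/C=C/S(=O)(=O)c4ccccc4OC)cc3F)ccnc2cc1OCCCN1CCC(C)CC1` is not yet measured. It differs from compound 2 in one place: methoxy in place of fluoro on an aromatic carbon. Among the measured compounds shown here, the same methoxyphenyl sulfonyl is already present in compound 1, which sits within the scatter of compound 2, and no step involving this change alone is on record. Compound 3 is therefore expected to show no step beyond the scatter, a 1.2-fold lower number from compound 2 to compound 3 (0.07 log units; within the scatter) in this assay. The estimate for compound 3 in this assay is 350 nM, with a range from 150 nM to 800 nM.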

Compound 3, half-maximal inhibitory concentration: 3000 nM
Estimate against measurement, compound 3: 8.6-fold (0.93 log units) below, and the stated range ends below it.
By their numbers in this assay, from the lowest: compounds 1 and 2 (each within the scatter of the next); then compound 3.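

In this assay, among these compounds, the ring position on the sulfonyl side proves sensitive: with 4-methylpiperidin-1-yl at the end of the chain, methoxy in place of fluoro on this aromatic carbon, ortho to a large group, gives a 7.3-fold higher number from compound 2 to compound 3 (0.86 log units; beyond the scatter) and is the first single change to show a step beyond the scatter. The other end of the molecule matters as well: with the 2-methoxyphenyl sulfonyl held constant, 4-methylpiperidin-1-yl in place of 4-methylpiperazin-1-yl gives a 9.4-fold higher number from compound 1 to compound 3 (0.97 log units; beyond the scatter) in the same read-out, so the methoxy group is tolerated in compound 1 but not in compound 3, and the two sites cannot be treated as independent on these compounds. No supporting data bear on the origin of either step.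

The compounds shown leave open whether the fluoro-to-methoxy step keeps its size with 4-methylpiperazin-1-yl on the chain, since only the methoxy member of that pair appears here. They also leave open how this ring position responds to a chloro or ethoxy group, or the chain end to a morpholine.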